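The compounds below may be only part of what the source reports. "The series", "measured", "known", "first", "only" and "open" are said of these compounds alone.

In a functional assay on MDA-MB-231 cells (Homo sapiens) for antiproliferative activity, read by MTT assay, with a stated time of 24 h (a higher number here means a weaker inhibitor, a lower number a stronger inhibitor), three compounds with a shared core have been measured so far. Compound 1 `CCCCc1oc2ccccc2c1C(=O)c1ccc(OCC(N)=O)cc1` reads > 50000 nM, which is a limit of the assay and not a number. Compound 3 `CCCCc1oc2ccccc2c1C(=O)c1ccc(OCC(=O)Nc2cccc(OC)c2)cc1` reads > 50000 nM, which is likewise only a limit. The series is thus marked by the limit of > 50000 nM in this assay, at which 2 of the 3 values shown sit, and compound 3 offers no number to start from. Compound 2 `CCCCc1oc2ccccc2c1C(=O)c1ccc(OCC(=O)N2CCN(C(=O)OC(C)(C)C)CC2)cc1` is the exception, with a measured 36900 nM.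

Compound 4 `CCCCc1oc2ccccc2c1C(=O)c1ccc(OCCCC(=O)N2CCCCC2)cc1` is not yet measured, and it differs from compound 3 as follows: 2-((piperidin-1-yl)carbonyl)ethyl in place of (3-methoxyphenyl)carbamoyl on a saturated chain carbon bound to an oxygen on an aromatic ring. In short, 2-((piperidin-1-yl)carbonyl)ethyl takes the place of (3-methoxyphenyl)carbamoyl on a saturated chain carbon bound to an oxygen on an aromatic ring.

Among the measured compounds shown here, the only measured step that bears directly on this change is a step that the two limits leave unreadable from compound 1 to compound 3. Both of its ends are limits, so it gives no size. The closest guide is compound 2 at 36900 nM, which also holds a six-membered non-aromatic ring. A reading for compound 4 close to that value or at the limit is therefore expected in this assay, with at most a modest gain in strength. The expected change is an at least 1.4-fold lower number from compound 3 to compound 4 (0.15 log units; that floor lies within the scatter). Compound 4 is estimated at 35000 nM, with an expected range from 12000 nM to 60000 nM.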

Compound 4, half-maximal inhibitory concentration: 36000 nM
The estimate for compound 4 lay 1.0-fold (0.01 log units) below the measured number; the measured number falls inside the stated range.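

With 2-((piperidin-1-yl)carbonyl)ethyl on the saturated chain carbon bound to an oxygen on an aromatic ring, compound 4 gives a number in this assay, 36000 nM, so a group at this position can give a measured number. The change reads as an at least 1.3-fold lower number from compound 3 to compound 4 (0.14 log units; that floor lies within the scatter), and against the simpler amide it reads as an at least 1.3-fold lower number from compound 1 to compound 4 (0.14 log units; that floor lies within the scatter); these are floors only, and neither establishes a real gain in strength. The step from compound 1 to compound 3 cannot be read, and the limit still marks much of the series: the limit of > 50000 nM in this assay, at which 2 of the 4 values shown sit.

The 2-((piperidin-1-yl)carbonyl)ethyl group brings its ring and its chain in together, and the compounds shown do not separate what each contributes to the reading of compound 4. From the compounds shown here alone, it also stays open how a carboxylic acid, a morpholine amide or a still longer chain at this place would read in this assay, and whether any such group could move the number clearly beyond the scatter.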